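The source may hold more compounds than are shown below. What is called first, only, known or untested is meant among the compounds shown, and "the series" means these compounds.

Measured compounds:
- compound 1, `Nc1ccccc1NC(=O)CCCCCN(CC(=O)NCc1ccccc1)C(=O)c1cccc2ccccc12`, in an assay on Sf9 cells for inhibition of protein deacetylase HDAC6 (Homo sapiens), read by fluorescence, with a stated time of 90 min; a lower number here means a stronger inhibitor, a higher number a weaker inhibitor: > 10000 nM
- compound 2, `Cc1cc(C)cc(C(=O)N(CCCCCC(=O)Nc2ccccc2N)CC(=O)NCc2ccccc2)c1`, in this assay: > 10000 nM

Compound 1 stands at a limit of the assay; its value of > 10000 nM is a limit, not a number. Compound 2 likewise returns only a limit, > 10000 nM. For the measured compounds named here, the one measured step, a step that the two limits leave unreadable from compound 1 to compound 2, is therefore unreadable, and the whole picture is summed up by the limit of > 10000 nM in this assay, at which 2 of the 2 values shown sit.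

Compound 3, `Nc1ccccc1NC(=O)CCCCCN(CC(=O)NC1CCCCC1)C(=O)c1cccc2ccccc12`, differs from compound 1 by cyclohexyl in place of benzyl on an amide-type nitrogen. Going by the values given here, no measured step touches the amide-type nitrogen that carries the benzyl group, so there is nothing to read a direction or size from. With both measured compounds sitting at the limit, compound 3 is expected to stay there as well, with a step that the limit leaves unreadable from compound 1 to compound 3 not expected to be resolved. The estimate for compound 3 in this assay is 20000 nM, in a range from 8000 nM to 60000 nM.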

Compound 3, half-maximal inhibitory concentration: > 10000 nM
Compound 3 ended at the assay's limit (the forecaster's own chance of this, stated with the estimate: 80%); the middle value lies beyond the limit too.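

In this assay compound 3 gives > 10000 nM, a limit and not a number, so the change from compound 1 to compound 3 yields no readable step. The compounds shown leave open what would bring a value within the measurable range: the limit of > 10000 nM in this assay, at which 3 of the 3 values shown sit.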